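The compounds below may be only part of what the source reports. "The series", "measured", "known", "first", "only" and "open" are said of these compounds alone.

Compound 3 `Cn1cc(-c2cnc(N)c(Oc3ccc(C(=O)Nc4cc(Cl)ccn4)cc3)n2)cn1` and compound 1 `Cc1noc(C)c1-c1cnc(N)c(Oc2ccc(C(=O)Nc3cc(Cl)ccn3)cc2)n1` share most of their structure, and their cores differ in that (1-methyl-1H-pyrazol-4-yl in place of 3,5-dimethyl-1,2-oxazol-4-yl on an aromatic carbon). In a functional assay on HeLa cells (Homo sapiens) for inhibition, read by MTT assay, with a stated time of 72 h (a higher number here means a weaker inhibitor, a lower number a stronger inhibitor), compound 1 gives 37900 nM, while compound 3 gives 40800 nM, a gap that is a 1.1-fold higher number from compound 1 to compound 3 (0.03 log units; within the scatter). Compound 2 `Cc1noc(C)c1-c1cnc(N)c(Oc2ccc(C(=O)Nc3ncccc3Cl)cc2)n1` arises from compound 1 by the change (3-chloropyridin-2-yl in place of 4-chloropyridin-2-yl on an amide-type nitrogen), and in this assay compound 2 gives 31900 nM, so that step is a 1.2-fold lower number from compound 1 to compound 2 (0.07 log units; within the scatter). Compound 4 `Cn1cc(-c2cnc(N)c(Oc3ccc(C(=O)Nc4ncccc4Cl)cc3)n2)cn1` has not been measured; it arises from compound 3 by the change (3-chloropyridin-2-yl in place of 4-chloropyridin-2-yl on an amide-type nitrogen), the same change as that from compound 1 to compound 2. Because the earlier step was a 1.2-fold lower number from compound 1 to compound 2 (0.07 log units; within the scatter), the step from compound 3 to compound 4 is expected to be a 1.2-fold lower number from compound 3 to compound 4 (0.08 log units; within the scatter). Compound 4 is therefore estimated at 34000 nM, within 17000 nM to 70000 nM.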

Compound 4, half-maximal inhibitory concentration: 36100 nM
Beside the measured number, compound 4's estimate is 1.1-fold (0.03 log units) below it; low and high end bracket the measured number.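

On the core of compound 3, putting 3-chloropyridin-2-yl in place of 4-chloropyridin-2-yl gives a 1.1-fold lower number from compound 3 to compound 4 (0.05 log units; within the scatter) in this assay, and this matches the earlier step: the same change on two cores in this assay, a 1.2-fold lower number (0.07 log units; within the scatter) from compound 1 to compound 2 and a 1.1-fold lower number (0.05 log units; within the scatter) from compound 3 to compound 4, 1.1-fold (0.02 log units) apart, within the scatter of two such steps. Putting 1-methyl-1H-pyrazol-4-yl in place of 3,5-dimethyl-1,2-oxazol-4-yl with the 3-chloropyridin-2-yl amide present gives a 1.1-fold higher number from compound 2 to compound 4 (0.05 log units; within the scatter) and also matches: the same change on two cores in this assay, a 1.1-fold higher number (0.03 log units; within the scatter) from compound 1 to compound 3 and a 1.1-fold higher number (0.05 log units; within the scatter) from compound 2 to compound 4, 1.1-fold (0.02 log units) apart, within the scatter of two such steps. Both changes carry between these cores, but every step lies within the scatter, so this shows only that neither has a readable effect here, not that a change with a larger effect would carry over in the same way. The compounds shown leave open whether an amine or a carboxylic acid in place of the chlorine would shift the number. They also leave open whether any such shift would hold on both cores.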